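N-Methylation of the aminomethyl group in the tetralin series

This account rests on a few compounds, and the source may have more. Where it says the series, first, only, none or still open, it means among the compounds named here.

Working notes on the set. Compound 3 `CCS(=O)(=O)Nc1cccc2c1CCCC2CN` carries an aminomethyl group on a saturated ring carbon of the shared core and in an assay on isolated protein for binding affinity to Alpha-1A adrenergic receptor (Rattus norvegicus), read by radioligand binding (a higher number here means a weaker inhibitor, a lower number a stronger inhibitor), compound 3 gives 794 nM. Compound 2 `CCS(=O)(=O)Nc1cccc2c1CCCC2c1c[nH]c(C)n1` has a 2-methyl-1H-imidazol-4-yl group at the same carbon and gives 794 nM; the one-point step no change at the digits printed from compound 2 to compound 3 (within the scatter) is within the scatter, so the two sit level, together the highest numbers of the three. Within the data shown here, compound 1 `CCS(=O)(=O)Nc1cc(F)cc2c1CCCC2c1c[nH]cn1` gives 83.2 nM, a lower number than compound 3 and beyond the scatter, but it differs in more than one place, so no single step is drawn from it.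

Compound 4 `CCS(=O)(=O)Nc1cccc2c1CCCC2CNC` is compound 3 with one change: methyl in place of hydrogen on an amine nitrogen. Among the measured compounds shown here, none of the measured steps touches the amine nitrogen; the only one-point step available, no change at the digits printed from compound 2 to compound 3 (within the scatter), left the number unchanged. The expected step is therefore a 1.0-fold higher number from compound 3 to compound 4 (0.00 log units; within the scatter), small or none beyond the scatter. For compound 4 the estimated value is 800 nM, in the range 300 nM to 2500 nM.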

Compound 4, inhibition constant: 1380 nM
Compound 4: middle estimate off by 1.7-fold (0.24 log units), on the low side; measured number inside the range.
By their numbers in this assay, from the lowest: compound 1; then compounds 2, 3 and 4 (each within the scatter of the next).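

In this assay, among these compounds, the first change at the amine nitrogen, methyl in place of hydrogen, gives a step that stays within the scatter (a 1.7-fold higher number from compound 3 to compound 4 (0.24 log units; within the scatter)), so this nitrogen carries a methyl with no reading of a change. The (methylamino)methyl group in place of 2-methyl-1H-imidazol-4-yl on the saturated ring carbon reads the same way (a 1.7-fold higher number from compound 2 to compound 4 (0.24 log units; within the scatter)), which leaves all three groups at this carbon level with one another in these compounds. No evidence shown bears on why these numbers stand as they do.

On these data alone, whether a second methyl on the nitrogen, a longer chain such as ethyl or an acetyl group there would give a step beyond the scatter stays open. Compound 1 differs from each of the others in more than one place, so its lower number is not yet tied to any single group.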